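Compound 3 to compound 4: methyl in place of bromo

A few compounds are considered here, and "the series" means these few. Any claim that something is new, unique, unknown or untested is made for them only; others in the source may bear on it.

The series is read in a functional assay on MGC-803 cells (Homo sapiens) for inhibition, read by sulforhodamine B assay (a higher number here means a weaker inhibitor, a lower number a stronger inhibitor), on a shared core, with the group on a double-bonded ring carbon varied. Compound 1 `O=C1C=C(NCc2ccccc2)C(=O)c2c1nc1n2[C@H]2OC[C@@H](O)[C@H]2OC1` carries benzylamino and gives 2670 nM as its value. Compound 2 `O=C1C=C(N2CCC2)C(=O)c2c1nc1n2[C@H]2OC[C@@H](O)[C@H]2OC1` carries azetidin-1-yl and reads > 16000 nM as a limit of the assay. Among the compounds with values here, compound 3 `O=C1C=C(Nc2ccc(Br)cc2)C(=O)c2c1nc1n2[C@H]2OC[C@@H](O)[C@H]2OC1` carries (4-bromophenyl)amino and gives 1010 nM as the lowest number so far.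

Compound 4 `Cc1ccc(NC2=CC(=O)c3nc4n(c3C2=O)[C@H]2OC[C@@H](O)[C@H]2OC4)cc1` differs from compound 3 by one exchange (methyl in place of bromo on an aromatic carbon) with methyl in place of bromo on an aromatic carbon, para to a large group. Every measured step replaces the whole group on the core, and none touches this aromatic position. The closest is the modest 2.6-fold lower number from compound 1 to compound 3 (0.42 log units; beyond the scatter) with 4-bromophenyl in place of benzyl on an amine nitrogen. Wider are an at least 5.9-fold higher number from compound 1 to compound 2 (0.77 log units; beyond the scatter) and an at least 15-fold lower number from compound 2 to compound 3 (1.19 log units; beyond the scatter) and both rest on the limit of compound 2. These sizes set no size for the present exchange.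

No step beyond the scatter is expected in this assay here, with compound 3 at 1010 nM as the anchor. The expected step is a 1.3-fold higher number from compound 3 to compound 4 (0.11 log units; within the scatter) on this estimate. For compound 4 the estimated value is 1300 nM with an expected range of 550 nM to 3500 nM as its lower and upper ends.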

Compound 4, half-maximal inhibitory concentration: 1420 nM
Compound 4: the middle estimate sits 1.1-fold (0.04 log units) below what was measured; measured number inside the range.
By their numbers in this assay, from the lowest: compounds 3, 4 and 1 (each within the scatter of the next, the first and the last beyond it). At a limit, above all of these: compound 2.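

In this assay, within the data shown here, the exchange of bromo for methyl on an aromatic carbon, para to a large group, gives the first direct reading at this position (a 1.4-fold higher number from compound 3 to compound 4 (0.15 log units; within the scatter)), so the two groups cannot be told apart here. The modest separation from the benzyl compound seen with the 4-bromophenyl group (a 2.6-fold lower number from compound 1 to compound 3 (0.42 log units; beyond the scatter)) does not carry over to the 4-methylphenyl group (a 1.9-fold lower number from compound 1 to compound 4 (0.27 log units; within the scatter)), which makes that separation a fragile feature of the series and not a general gain from an aryl group on the amine nitrogen. The large step from the azetidine (an at least 11-fold lower number from compound 2 to compound 4 (1.05 log units; beyond the scatter)) holds for (4-methylphenyl)amino as it did for (4-bromophenyl)amino, but it is read against a limit for compound 2, not a number: (the limit of > 16000 nM in this assay, at which 1 of the 4 values shown sits).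

Only bromo and methyl are shown at this aromatic carbon, so it stays open whether a methoxy group, a carboxylic acid or an amine there would move the value beyond the scatter. As far as these compounds go, it also stays open whether the same exchange would read alike on a benzyl group, where the shared core carries a different link to the ring.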